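Lengthening a Side Chain on a Nucleoside-Like Scaffold

A few compounds are considered here, and "the series" means these few. Any claim that something is new, unique, unknown or untested is made for them only; others in the source may bear on it.

This study examines a set of nucleoside-like compounds that share a common core and differ in two places: the group attached to the alkyne arm and the group on the aromatic ring that sits on the core. They were tested in an ADME assay on HEL cells (Homo sapiens) for cytotoxicity, read by cell counting, with a stated time of 3 days; on this read-out higher numbers stand for lower toxicity in this test and lower numbers for higher toxicity in this test. Compound 1, with the structure `CC(=O)OC[C@H]1O[C@@H](n2cc3c(C#CCO)c(-c4ccc(C)cc4)oc3nc2=O)C[C@@H]1OC(C)=O`, carries a 4-methylphenyl group and a short hydroxylated alkyne arm; in this assay compound 1 is recorded as "not determined" (no result reported), so it has no number to stand on. Compound 2, `CC(=O)OC[C@H]1O[C@@H](n2cc3c(C#Cc4ccc(C)cc4)c(-c4ccc(C)cc4)oc3nc2=O)C[C@@H]1OC(C)=O`, keeps the 4-methylphenyl group but carries a second aromatic ring on the alkyne arm, and in this assay compound 2 gives 8770 nM. Compound 3, `CCCCCc1ccc(-c2oc3nc(=O)n([C@H]4C[C@H](OC(C)=O)[C@@H](COC(C)=O)O4)cc3c2C#CCCO)cc1`, carries a 4-pentylphenyl group together with a longer hydroxylated arm, and in this assay compound 3 gives 2660 nM.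

The step to be followed here is from compound 1 to compound 4, whose structure is `CCCCCc1ccc(-c2oc3nc(=O)n([C@H]4C[C@H](OC(C)=O)[C@@H](COC(C)=O)O4)cc3c2C#CCO)cc1`. The change is butyl in place of hydrogen on a saturated chain carbon bound to an aromatic carbon. Because compound 1 has no measured value, the size of this step cannot be computed from the data. The expectation for compound 4 rests on compound 3, whose aromatic ring carries the same pentyl group and which gives 2660 nM. Compound 4 is expected to give 3000 nM, with a range from 1000 nM to 9000 nM.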

Compound 4, half-maximal cytotoxic concentration: 3800 nM
Compound 4: middle estimate off by 1.3-fold (0.10 log units), on the low side; measured number inside the range.
By their numbers in this assay, from the lowest: compounds 3 and 4 (each within the scatter of the next); then compound 2.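

In this assay, among these compounds, the two compounds carrying the 4-pentylphenyl group give the first comparison at the alkyne arm. They show a 1.4-fold higher number from compound 3 to compound 4 (0.15 log units; within the scatter) with hydroxy in place of hydroxymethyl on a saturated chain carbon bound to a triple-bonded carbon. With the aromatic group held fixed, this difference in the hydroxylated arm does not separate the two compounds on this read-out, so within this pair the arm's length leaves the number inside the usual noise of the test. Nothing among the data shown offers an explanation for this result.

As far as these compounds go, the step from methyl to pentyl on the aromatic ring cannot be read: compound 1 has no number to set against compound 4, so what the longer chain does in this test stays open. Among the compounds shown here, also open is how the arm behaves with an amine or a carboxylic acid in place of the hydroxy, or with a chain longer than the one in compound 3.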